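Trifluoromethyl for ethyl: from compound 3 to compound 4

A few compounds are considered here, and "the series" means these few. Any claim that something is new, unique, unknown or untested is made for them only; others in the source may bear on it.

Going by the values given here, compound 3 `CCc1cccc(Nc2nc3nonc3nc2O)c1` gives 25200 nM in an assay on mitochondria from L6 cells (Rattus norvegicus) for activation, with a stated time of 90 min (on this read-out lower numbers stand for an effect already at smaller amounts and higher numbers for an effect only at larger amounts of compound), the second highest of the three numbers so far. Compound 1 `COc1cccc(Nc2nc3nonc3nc2O)c1` gives 75400 nM in this assay, and compound 2 `Oc1nc2nonc2nc1Nc1ccc(OCC(F)(F)F)c(C(F)(F)F)c1` gives 4000 nM. Among the compounds with values here, the only single-site step measured so far, a 3.0-fold lower number from compound 1 to compound 3 (0.48 log units; beyond the scatter), shows that exchanging the group on this aromatic carbon shifts the number by a modest amount.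

Compound 4 `Oc1nc2nonc2nc1Nc1cccc(C(F)(F)F)c1` differs from compound 3 by trifluoromethyl in place of ethyl on an aromatic carbon. Within the data shown here, no measured step places a trifluoromethyl at this spot; compound 2, which carries a trifluoromethyl among other groups, gives the lowest number seen. A modest step of roughly the size of a 3.0-fold lower number from compound 1 to compound 3 (0.48 log units; beyond the scatter), in the same direction, is therefore expected. For compound 4 the expected step is a 2.1-fold lower number from compound 3 to compound 4 (0.32 log units; beyond the scatter). Compound 4 is estimated at 12000 nM, in a range from 5000 nM to 30000 nM.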

Compound 4, half-maximal effective concentration: 13300 nM
The estimate for compound 4 lay 1.1-fold (0.04 log units) below the measured number; low and high end bracket the measured number.
By their numbers in this assay, from the lowest: compound 2; then compounds 4 and 3 (each within the scatter of the next); then compound 1.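

Notes: in this assay, trifluoromethyl and ethyl on this aromatic carbon cannot be told apart, with a 1.9-fold lower number from compound 3 to compound 4 (0.28 log units; within the scatter) as the step. Against methoxy the exchange counts for more: a 5.7-fold lower number from compound 1 to compound 4 (0.75 log units; beyond the scatter) is a modest step, in the same direction as a 3.0-fold lower number from compound 1 to compound 3 (0.48 log units; beyond the scatter) for ethyl. With trifluoromethyl in place, hydrogen for 2,2,2-trifluoroethoxy gives a 3.3-fold higher number from compound 2 to compound 4 (0.52 log units; beyond the scatter) and so also a modest step.

Nothing at hand explains these steps. As far as these compounds go, whether an amine, a carboxylic acid or a longer chain on this aromatic carbon would give a lower number remains open.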